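A few compounds are considered here, and "the series" means these few. Any claim that something is new, unique, unknown or untested is made for them only; others in the source may bear on it.

Compound 3, `COc1cc2c(c(OC)c1)C(=O)N(c1cccc(C(=O)N3CCCCC3)c1)CC2`, gives 10800 nM in a functional assay on A-431 cells (Homo sapiens) for antiproliferative activity, read by MTT assay, with a stated time of 72 h; on this read-out higher numbers stand for weaker inhibition and lower numbers for stronger inhibition. Among the three compounds measured so far, compound 3 stands second highest. Compound 2, `COc1cc(OC)c2c(=O)n(-c3cccc(C(F)(F)F)c3)ccc2c1`, gives 14800 nM in this assay, a number that lies within the scatter of compound 3. Compound 1, `COc1cc(OC)c2c(=O)n(-c3cccc(F)c3)ccc2c1`, gives 4170 nM in this assay, a number lower than that of compound 3 and beyond the scatter. Compound 4, `COc1cc(O)c2c(c1)CCN(c1cccc(C(=O)N3CCCCC3)c1)C2=O`, has not yet been measured. It differs from compound 3 in one place: hydrogen in place of methyl on an oxygen on an aromatic ring, a change that, cut one bond further out, reads methoxy to hydroxy. Among the compounds with values here, the only step between measured compounds that differ in one place is a 3.5-fold higher number from compound 1 to compound 2 (0.55 log units; beyond the scatter), trifluoromethyl in place of fluoro on an aromatic carbon. That change is of a different kind and offers no direct guide to what removing a methyl from an oxygen will do. Within the data shown here, with no comparable step to draw on, the expected step is a 1.1-fold lower number from compound 3 to compound 4 (0.03 log units; within the scatter), with no direction beyond the scatter. Compound 4 is therefore estimated at 10000 nM, within a range from 3500 nM to 30000 nM.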

Compound 4, half-maximal inhibitory concentration: 5320 nM
Beside the measured number, compound 4's estimate is 1.9-fold (0.27 log units) above it; the measured number falls inside the stated range.
By their numbers in this assay, from the lowest: compounds 1 and 4 (each within the scatter of the next); then compounds 3 and 2 (each within the scatter of the next).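

Replacing the methyl on this oxygen with hydrogen, methoxy to hydroxy, gives a 2.0-fold lower number from compound 3 to compound 4 (0.31 log units; beyond the scatter) in this assay. This is the first single change shown at this oxygen, and it shows that the methyl is not required for the activity seen here: losing it lowers the number, a modest step but one that lies beyond the scatter. No measurement at hand says what lies behind this step.

A single pair cannot show whether hydrogen on this oxygen is what matters or whether any small replacement of the methoxy would do as well; an ethoxy group or an amine in the same place would begin to separate these possibilities. On these data alone, it also remains open whether the same change at the methoxy that compound 4 keeps would give a similar step.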